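Working notes: aromatic substituent swaps in a small series

A few compounds are considered here, and "the series" means these few. Any claim that something is new, unique, unknown or untested is made for them only; others in the source may bear on it.

Compound 3 `CC(=O)c1ccc(OCc2cccc(F)c2)cc1` gives 83.1 nM in an assay on isolated protein for inhibition of Amine oxidase [flavin-containing] B (Homo sapiens), read by Amplex Red, with a stated time of 15 min; a lower number here means a stronger inhibitor, a higher number a weaker inhibitor. Its number sits at the low end of the three measured, yet compound 1 `CC(=O)c1ccc(OCc2cccc(C)c2)cc1` with 86.3 nM and compound 2 `CC(=O)c1ccc(OCc2cccc([N+](=O)[O-])c2)cc1` with 104 nM lie close by: a 1.0-fold lower number from compound 1 to compound 3 (0.02 log units; within the scatter) and a 1.3-fold lower number from compound 2 to compound 3 (0.10 log units; within the scatter) both fall within the scatter, as does a 1.2-fold higher number from compound 1 to compound 2 (0.08 log units; within the scatter). Among the compounds with values here, three different groups at this place have thus produced no step beyond the scatter, so no compound can be set apart as the stronger or weaker inhibitor.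

Compound 4 `CC(=O)c1ccc(OCc2cccc(C(F)(F)F)c2)cc1` is not yet measured. The change from compound 3 is trifluoromethyl in place of fluoro on an aromatic carbon. The measured steps that bear on it are the swaps among methyl, nitro and fluoro at the same place, none of which moved the number beyond the scatter; a fourth group at this place is therefore expected to behave alike, and the step of a 1.0-fold higher number from compound 3 to compound 4 (0.01 log units; within the scatter) is expected to remain within the scatter. The estimate for compound 4 in this assay is 85 nM, with a range from 40 nM to 180 nM.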

Compound 4, half-maximal inhibitory concentration: 58.2 nM
Compound 4: middle estimate off by 1.5-fold (0.16 log units), on the high side; the measured number falls inside the stated range.
By their numbers in this assay, from the lowest: compounds 4, 3, 1 and 2 (each within the scatter of the next).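

Trifluoromethyl brings 4 heavy atoms where fluoro had 1, yet the number in this assay stays within the scatter: a 1.4-fold lower number from compound 3 to compound 4 (0.15 log units; within the scatter). The same holds against the other two groups, with a 1.5-fold lower number from compound 1 to compound 4 (0.17 log units; within the scatter) and a 1.8-fold lower number from compound 2 to compound 4 (0.25 log units; within the scatter), so all steps among the four groups at this place remain within the scatter and none of the four compounds can be set apart, even with the added heavy atoms of this change. Nothing at hand gives a reason for the values in this series.

From the compounds shown here alone, whether an amine, a carboxylic acid or a longer chain on this aromatic carbon would give a step beyond the scatter remains open. Also open, going by these compounds, is whether the same swaps elsewhere on the shared core would stay equally flat.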